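The source may report more compounds than this note shows. Statements on the series, on what has been measured and on what is new or still open speak of the compounds shown alone.

Compound 1, `CC1=CC(=O)OC(CSc2nc(-c3ccccc3)c(-c3ccccc3)[nH]2)C1`: 200 nM
Compound 2, `O=C1CCCC(CSc2nc(-c3ccccc3)c(-c3ccccc3)[nH]2)O1`: 740 nM

In an assay on microsomes from liver for inhibition of sterol O-acyltransferase 1 (Rattus norvegicus) (a higher number here means a weaker inhibitor, a lower number a stronger inhibitor), compound 2 stands at the higher of the two numbers, and its nearest neighbour is compound 1, which gives 200 nM. Within the data shown here, the only measured step, a 3.7-fold higher number from compound 1 to compound 2 (0.57 log units; beyond the scatter), swapped one six-membered non-aromatic ring for another. Compound 3, `O=C1CC(O)CC(CSc2nc(-c3ccccc3)c(-c3ccccc3)[nH]2)O1`, differs from compound 2 by hydroxy in place of hydrogen on a saturated ring carbon. Among the measured compounds shown here, no measured step bears on adding a hydroxy here, so no change beyond the scatter is expected, with a wide margin. Compound 3 is estimated at 900 nM, between 300 nM and 2700 nM, a step of a 1.2-fold higher number from compound 2 to compound 3 (0.09 log units; within the scatter).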

Compound 3, half-maximal inhibitory concentration: 910 nM
Compound 3: middle estimate off by 1.0-fold (0.00 log units), on the low side, and the stated range covers the measured number.
By their numbers in this assay, from the lowest: compound 1; then compounds 2 and 3 (each within the scatter of the next).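

In this assay, hydroxy in place of hydrogen on this saturated ring carbon, two ring bonds from the ring atom that bears a large group, leaves the reading within the scatter, with a 1.2-fold higher number from compound 2 to compound 3 (0.09 log units; within the scatter) as the step. The added hydroxy does not close the gap to compound 1, and a 4.6-fold higher number from compound 1 to compound 3 (0.66 log units; beyond the scatter) remains beyond the scatter. Nothing available explains this result. The compounds shown leave open whether a methoxy, an amine or a carboxylic acid on the same ring carbon would read like hydroxy, and whether hydroxy would have the same small effect on the ring of compound 1.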